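Replacing an Aryl Group on a Bicyclic Lactam Core

The compounds below may be only part of what the source reports. "The series", "measured", "known", "first", "only" and "open" are said of these compounds alone.

Among the compounds with values here, compound 1 `COc1ccc(C2=C(c3ccc(SC)cc3)CC3CCCN3C2=O)cc1O` is one of two compounds measured in a functional assay on NCI-H520 cells (Homo sapiens) for cytotoxicity; a higher number here means a weaker inhibitor of growth, a lower number a stronger inhibitor of growth. In that assay compound 1 gives 6000 nM, the highest of the two numbers. Compound 2 `COc1ccc(C2=C(c3ccc(SC)cc3)CC3CCCN3C2=O)cc1` differs from compound 1 in one place, hydrogen in place of hydroxy on an aromatic carbon, and compound 2 gives 800 nM; the step is a 7.5-fold lower number from compound 1 to compound 2 (0.88 log units; beyond the scatter). Compound 3 `CSc1ccc(C2=C(c3ccc(F)cc3)C(=O)N3CCCC3C2)cc1` has not yet been measured. Its change from compound 1 is 4-fluorophenyl in place of 3-hydroxy-4-methoxyphenyl on a double-bonded ring carbon. Within the data shown here, the group that leaves carries the hydroxy that was also removed in the step of a 7.5-fold lower number from compound 1 to compound 2 (0.88 log units; beyond the scatter), so that step bears on the present one, although compound 3 additionally loses the methoxy and gains a fluorine, for which no measured step exists. Compound 3 is therefore expected to show a modest step toward a lower number, a 6.0-fold lower number from compound 1 to compound 3 (0.78 log units; beyond the scatter). The estimate for compound 3 is 1000 nM, with a range from 300 nM to 4000 nM.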

Compound 3, concentration for 50% growth inhibition: 250 nM
For compound 3 the middle estimate is 4.0-fold (0.60 log units) above the measured one; the measured number lies below the stated range.
By their numbers in this assay, from the lowest: compound 3; then compound 2; then compound 1.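

In this assay, swapping the whole 3-hydroxy-4-methoxyphenyl group for 4-fluorophenyl is a large step (a 24-fold lower number from compound 1 to compound 3 (1.38 log units; beyond the scatter)), well beyond what losing the hydroxy alone gave (a 7.5-fold lower number from compound 1 to compound 2 (0.88 log units; beyond the scatter)). The methoxy therefore counts too: with the hydroxy already gone, fluoro in place of methoxy on an aromatic carbon still gives a further modest step (a 3.2-fold lower number from compound 2 to compound 3 (0.51 log units; beyond the scatter)), so this ring carbon's aryl group need not keep either oxygen substituent for growth inhibition in these compounds. Nothing measured here explains why these changes lower the number.

The compounds shown leave open whether the fluorine itself helps or whether simply removing the methoxy would do as much, which a plain phenyl group would test. A chloro or a methyl group in the same place, or an amine, would show how much this group's substituent can vary.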